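Replacing amino with methyl in compound 2

The source may report more compounds than this note shows. Statements on the series, on what has been measured and on what is new or still open speak of the compounds shown alone.

In a functional assay on RBL-2H3 cells (Rattus norvegicus) for inhibition, read by neutral red uptake, with stated times of 30 min and 1 h (on this read-out higher numbers stand for weaker inhibition and lower numbers for stronger inhibition), compound 1 (`COc1ccc(CN(CCN(C)C)c2ccccc2)cc1`) gives 143 nM and compound 2 (`COc1ccc(CN(CCN(C)C)c2ccc(N)cn2)cc1`) gives 1340 nM as the higher of the two numbers, which means the weaker inhibition. Compound 3 (`COc1ccc(CN(CCN(C)C)c2ccc(C)cn2)cc1`) carries methyl in place of amino on an aromatic carbon, so that 5-aminopyridin-2-yl becomes 5-methylpyridin-2-yl (methyl in place of amino on an aromatic carbon). Among the measured compounds shown here, the only measured step that bears on this change is a 9.4-fold higher number from compound 1 to compound 2 (0.97 log units; beyond the scatter) with 5-aminopyridin-2-yl in place of phenyl on an amine nitrogen, and it lies beyond the scatter. That step exchanges the whole aromatic group, so the data do not show how much of it goes with the amino group and how much with the ring nitrogen. Compound 3 keeps the ring nitrogen and loses the amino group, so a partial return toward compound 1 (143 nM) is expected, which would be a lower number in this assay than that of compound 2. The expected change is a 2.7-fold lower number from compound 2 to compound 3 (0.43 log units; beyond the scatter) as an estimate from this single step. The estimate for compound 3 is 500 nM with an expected range from 150 nM to 1500 nM in this measurement.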

Compound 3, half-maximal inhibitory concentration in the RBL-2H3 assay: 28.9 nM
The estimate for compound 3 lay 17-fold (1.24 log units) above the measured number, outside the stated range (below it).
By their numbers in the RBL-2H3 assay, from the lowest: compound 3; then compound 1; then compound 2.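

In the RBL-2H3 assay, a 46-fold lower number from compound 2 to compound 3 (1.67 log units; beyond the scatter) shows that this position on the ring alone carries a large effect, one that the earlier exchange of the whole aromatic group could not separate from the ring nitrogen. In the RBL-2H3 assay, a 4.9-fold lower number from compound 1 to compound 3 (0.69 log units; beyond the scatter) shows that a ring with this nitrogen can give stronger inhibition than phenyl once it bears methyl, so the ring nitrogen does not by itself bring the loss seen in a 9.4-fold higher number from compound 1 to compound 2 (0.97 log units; beyond the scatter). In a physicochemical assay for lipophilicity (a lower number here means a more polar compound, a higher number a more lipophilic compound), compound 2 gives 2.56 and compound 3 gives 3.79. In the physicochemical assay, the gain in inhibition from amino to methyl goes together with a measured rise in lipophilicity, which this single pair cannot establish as its cause: the measured partition coefficient of compound 2, 2.56, and of compound 3, 3.79, a number 1.23 log units higher (beyond the scatter).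

The compounds shown leave open whether inhibition follows lipophilicity beyond this pair, or whether the gain depends on methyl itself rather than on the loss of amino. Ethyl, methoxy or chloro at this position would test the first two readings, and a pyridin-2-yl ring with hydrogen there would give the share of the ring nitrogen alone.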